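This account rests on a few compounds, and the source may have more. Where it says the series, first, only, none or still open, it means among the compounds named here.

Working notes on the series, read in a functional assay on MDA-MB-231 cells (Homo sapiens) for antiproliferative activity, read by MTT assay; on this read-out higher numbers stand for weaker inhibition and lower numbers for stronger inhibition. Compound 1 (`CCCC/C=C\CCCCCCCCCc1cc(=O)c2c(O)cc(O)c(C)c2o1`) gives 6790 nM, and compound 2 (`CCCCC/C=C\C/C=C\CCCCCCCc1cc(=O)c2c(O)cc(O)c(C)c2o1`) sits level with it at 6790 nM. Compound 3 (`CCCC/C=C\CCCCCCCCCc1cc(=O)c2c(O)c(C)c(O)c(C)c2o1`) gives > 87000 nM, which is a limit of the assay and not a number. Compound 1 therefore stands at the lower of the two values that are true numbers, shared with compound 2.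

The next structure is compound 4 (`CCCC/C=C\CCCCCCCCCc1cc(=O)c2c(O)cc(OCOC)c(C)c2o1`), with the change methoxymethyl in place of hydrogen on an oxygen on an aromatic ring: hydroxy becomes methoxymethoxy. Two measured steps offer guidance, and neither alters that oxygen, so the read-across is indirect. Deca-1,4-dien-1-yl in place of oct-3-en-1-yl on the chain gives no change at the digits printed from compound 1 to compound 2 (within the scatter). Methyl in place of hydrogen on an aromatic carbon gives an at least 12-fold higher number from compound 1 to compound 3 (1.10 log units; beyond the scatter). The chain step says little about a change on the core. Within the data shown here, the closer guide is compound 3, the only core change measured so far, with its large step of an at least 12-fold higher number from compound 1 to compound 3 (1.10 log units; beyond the scatter). A clear move toward weaker inhibition is therefore expected, though with wide uncertainty and probably short of that step. The expected change is a 2.7-fold higher number from compound 1 to compound 4 (0.42 log units; beyond the scatter). The estimated value for compound 4 is 18000 nM, with an expected range of 5000 nM to 70000 nM.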

Compound 4, half-maximal inhibitory concentration: > 87000 nM
Compound 4 gave a limit, no number; the forecaster's own chance of this, stated with the estimate: 25%; middle value at least 4.8-fold (0.68 log units) from the limit.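

In this assay, among these compounds, methoxymethyl in place of hydrogen on this oxygen gives an at least 12-fold higher number from compound 1 to compound 4 (1.10 log units; beyond the scatter), the first measured change at this oxygen and a large move toward weaker inhibition. Compound 4 reads > 87000 nM, which is a limit of the assay and not a number. Among the compounds shown here, until now the only measured change on the shared core was methyl in place of hydrogen on an aromatic carbon, with an at least 12-fold higher number from compound 1 to compound 3 (1.10 log units; beyond the scatter); the oxygen is now a second place on the core where a single change takes the series well away from compound 1, while the chain change gives no change at the digits printed from compound 1 to compound 2 (within the scatter).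

The full size of the step on this oxygen stays unread, and the result can only be given as a bound: the limit of > 87000 nM in this assay, at which 2 of the 4 values shown sit A smaller group on this oxygen, such as methyl or acetyl, would show whether the hydroxy hydrogen must remain free or whether the outcome is specific to methoxymethyl.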